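Swapping Ethoxycarbonyl for Methoxy on an Aromatic Carbon

A few compounds are considered here, and "the series" means these few. Any claim that something is new, unique, unknown or untested is made for them only; others in the source may bear on it.

Compound 3 `CCOC(=O)c1cccc(NC(=O)N[C@@H](C)c2ccccc2)c1` gives 100% in an ADME assay on the whole organism with Oryza sativa as the target, tested at 0.1 uM; a lower number here means a stronger effect, a higher number a weaker effect of the compound at the concentration tested. It stands level with compound 1 `CCc1cccc(NC(=O)N[C@@H](C)c2ccccc2)c1`, which gives 100%, the two together the highest of three numbers, and compound 2 `C[C@H](NC(=O)Nc1cccc(C(F)(F)F)c1)c1ccccc1` gives 94%, with a number 6 percentage points lower from compound 1 to compound 2 (within the scatter). Compound 4 `COc1cccc(NC(=O)N[C@@H](C)c2ccccc2)c1` differs from compound 3 by methoxy in place of ethoxycarbonyl on an aromatic carbon. Within the data shown here, the steps that bear on this change are the two earlier swaps at the same aromatic carbon, no change at the digits printed from compound 1 to compound 3 (within the scatter) and a number 6 percentage points higher from compound 2 to compound 3 (within the scatter), both within the scatter, so no step beyond the scatter is expected in this assay. Compound 4 is therefore estimated to give 98%, between 86% and 100%, which means an expected a number 2 percentage points lower from compound 3 to compound 4 (within the scatter).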

Compound 4, a percentage reported as activity, at one concentration (the size of the read-out at that concentration, not a potency): 101%
The estimate for compound 4 lay 3 percentage points below the measured number; the measured number lies above the stated range.
By their numbers in this assay, from the lowest: compounds 2, 1, 3 and 4 (each within the scatter of the next).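

In this assay methoxy at this aromatic carbon gives a number 1 percentage points higher from compound 3 to compound 4 (within the scatter) and a number 1 percentage points higher from compound 1 to compound 4 (within the scatter) and also a number 7 percentage points higher from compound 2 to compound 4 (within the scatter) as its steps, so it stays within the scatter of all three earlier groups. Going from ethoxycarbonyl with 5 heavy atoms and a double bond outside aromatic rings to methoxy with 2 heavy atoms and no such bond leaves the read-out within the scatter. Nothing available here accounts for this result.

Going by these compounds, whether an amine, a carboxylic acid or a longer chain at this carbon would move the read-out beyond the scatter stays open. So does the effect of any of these groups elsewhere on the ring.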